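Thiazole-acetic acid series: aryl swap from compound 1 to compound 4

The source may hold more compounds than are shown below. What is called first, only, known or untested is meant among the compounds shown, and "the series" means these compounds.

Measured so far:
compound 1, `COc1ccc(OC)c(-c2nc(C(c3ccccc3)c3ccccc3)sc2CC(=O)O)c1`, 80%
compound 2, `O=C(O)Cc1sc(Cc2ccccc2)nc1-c1ccc(Cl)cc1`, 50%
compound 3, `O=C(O)Cc1sc(C(c2ccc(F)cc2)c2ccc(F)cc2)nc1-c1ccc(Cl)cc1`, 80%

All three compounds share one core and were read in an in vitro functional assay on HEK285-7 cells for antagonist activity at prostaglandin D2 receptor 2 (Homo sapiens), read by BRET and beta-arrestin recruitment; a lower number here means a smaller maximal response, a higher number a larger maximal response. Compound 1 stands level with compound 3 at the digits reported, and the two of them give the highest numbers of the three; the gap between them lies within the scatter, so no order between compound 1 and compound 3 is claimed. Compound 2 sits below compound 1, and that gap lies beyond the scatter. Going by the values given here, compound 2 and compound 3 each differ from compound 1 in more than one place, so no single-point step between measured compounds is available, and the bearing of any one change on the largest response reached is not settled by these data.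

Compound 4, `O=C(O)Cc1sc(C(c2ccccc2)c2ccccc2)nc1-c1cccc(F)c1`, is not yet measured. It differs from compound 1 as follows: 3-fluorophenyl in place of 2,5-dimethoxyphenyl on an aromatic carbon. The large group and the carboxymethyl group of compound 1 are kept.

Among the compounds with values here, with no single-point step on record, the expectation for compound 4 rests on compound 1 giving 80% and compound 3 giving 80%, both carrying a large group of the same kind at the core. Compound 4 is estimated at 75%, with a range from 55% to 95%. The step this estimate implies, a number 5 percentage points lower from compound 1 to compound 4 (within the scatter), is expected to fall within the scatter, with no change beyond it in either direction.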

Compound 4, largest response reached (reported as efficacy), in percent of the reference or control that the assay uses: 80%
Compound 4: the middle estimate sits 5 percentage points below what was measured, within the range that was stated.
By their numbers in this assay, from the lowest: compound 2; then compounds 1, 3 and 4 (each within the scatter of the next).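

In this assay, going by these compounds alone, 3-fluorophenyl in place of 2,5-dimethoxyphenyl on the aromatic carbon next to the ring nitrogen gives no change at the digits printed from compound 1 to compound 4 (within the scatter) and is the only single-point step so far. With the large group and the carboxymethyl group kept, this position therefore takes a change from 2,5-dimethoxyphenyl, with its 2 hydrogen-bond acceptors, to 3-fluorophenyl, with 0, and the largest response reached stays within the scatter. The data on hand offer no independent measurement that would explain this outcome.

The finding rests on one pair and covers only these two substituted phenyl groups, so it does not show how the large group or the carboxymethyl group bears on the response in a single-point comparison. Also open, as far as these compounds go, is how the same aromatic carbon reads with an unsubstituted phenyl, a pyridine ring, an aminomethyl group or a small alkyl chain in place of the aryl groups seen here.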